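A few compounds are considered here, and "the series" means these few. Any claim that something is new, unique, unknown or untested is made for them only; others in the source may bear on it.

Of the compounds shown here, three built on one shared core have been tested in a functional assay on MCF7 cells (Homo sapiens) for inhibition, read by sulforhodamine B assay, with a stated time of 72 h; a higher number here means a weaker inhibitor, a lower number a stronger inhibitor. Compound 1 `COc1ccc2cc(C(C)c3nnc4n3N=C(c3ccc(OC(F)(F)F)cc3)CS4)ccc2c1` gives 8800 nM in this assay. Compound 2 `COc1ccc2cc(C(C)c3nnc4n3N=C(c3ccc(Br)cc3)CS4)ccc2c1` gives 11500 nM. Compound 3 `COc1ccc2cc(C(C)c3nnc4n3N=C(c3ccc(Cl)cc3)CS4)ccc2c1` gives 10100 nM. Among these three numbers compound 3 stands second highest, with compound 2 nearest to it and compound 1 furthest, yet all three results lie within the scatter of one another, so none of them can be called a stronger or a weaker inhibitor than the rest. The steps between them are a 1.3-fold higher number from compound 1 to compound 2 (0.12 log units; within the scatter), a 1.1-fold higher number from compound 1 to compound 3 (0.06 log units; within the scatter) and a 1.1-fold lower number from compound 2 to compound 3 (0.06 log units; within the scatter); each exchanges one group at the same aromatic carbon, and none moves the number beyond the scatter.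

Compound 4 `COc1ccc2cc(C(C)c3nnc4n3N=C(c3ccc(C)cc3)CS4)ccc2c1` has not yet been measured. It differs from compound 3 in one place: methyl in place of chloro on an aromatic carbon. The three measured steps, each an exchange of a single group at this same position, bear directly on this change, and every one of them stayed within the scatter. The step of a 1.0-fold lower number from compound 3 to compound 4 (0.00 log units; within the scatter) is therefore expected to show no change beyond the scatter in this assay, in no particular direction. Compound 4 is estimated at 10000 nM, with a likely range from 5000 nM to 20000 nM.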

Compound 4, half-maximal inhibitory concentration: 11000 nM
Estimate against measurement, compound 4: 1.1-fold (0.04 log units) below; low and high end bracket the measured number.
By their numbers in this assay, from the lowest: compounds 1, 3, 4 and 2 (each within the scatter of the next).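

Within the data shown here, the exchange of chloro for methyl, the 4-chlorophenyl to 4-methylphenyl difference, puts a plain carbon group on this aromatic carbon, whereas the earlier compounds carried only two halogens and trifluoromethoxy there. In this assay, methyl cannot be told apart from any of these three groups: the steps are a 1.1-fold higher number from compound 3 to compound 4 (0.04 log units; within the scatter) for chloro, a 1.0-fold lower number from compound 2 to compound 4 (0.02 log units; within the scatter) for bromo and a 1.3-fold higher number from compound 1 to compound 4 (0.10 log units; within the scatter) for trifluoromethoxy. So across these four compounds, all six exchanges at this position stay within the scatter, and the series now spans a single-carbon group as well as halogens and an oxygen-linked group, though no measurement offered here explains why the numbers stay together.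

All four groups are uncharged and carry no hydrogen-bond donor, so the compounds shown leave open what an amine, a carboxylic acid or a longer chain such as hexyl would do on this same aromatic carbon. Among these compounds, they also leave open whether the rest of the shared core is as forgiving, since every compound here keeps it unchanged while only this one group varies.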